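Bromo to trifluoromethyl in the thioamide series

This account rests on a few compounds, and the source may have more. Where it says the series, first, only, none or still open, it means among the compounds named here.

compound 1 `COc1ccc(Cl)cc1C(=O)Nc1cc(Br)ccc1O`: 4090 nM
compound 2 `COc1cc(Cl)ccc1C(=S)Nc1cc(Cl)ccc1O`: 8490 nM
compound 3 `COc1cc(Cl)ccc1C(=S)Nc1cc(Br)ccc1O`: 6530 nM

In a functional assay on HepG2 cells (Homo sapiens) for cytotoxicity, with a stated time of 24 h (on this read-out lower numbers stand for stronger inhibition and higher numbers for weaker inhibition), compound 3 gives 6530 nM, a number within the scatter of both other compounds, so it stands out from neither. The next structure is compound 4 `COc1cc(Cl)ccc1C(=S)Nc1cc(C(F)(F)F)ccc1O`, which carries trifluoromethyl in place of bromo on an aromatic carbon, para to a hydroxy group: trifluoromethyl in place of bromo on an aromatic carbon.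

Going by the values given here, one measured step bears on this change. Bromo in place of chloro on an aromatic carbon gave a 1.3-fold lower number from compound 2 to compound 3 (0.11 log units; within the scatter). Compound 1 differs from compound 3 in more than one place and offers no clean comparison. Among the compounds with values here, no trifluoromethyl compound has been measured yet, so the expectation rests on that single small step and remains loose. No shift beyond the scatter is expected in this assay, and no direction can be argued from these data.

The expected change is a 1.1-fold lower number from compound 3 to compound 4 (0.04 log units; within the scatter). For compound 4 the estimated value is 6000 nM, with an expected range of 3000 nM to 12000 nM.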

Compound 4, half-maximal inhibitory concentration: 5740 nM
For compound 4 the middle estimate is 1.0-fold (0.02 log units) above the measured one; measured number inside the range.
By their numbers in this assay, from the lowest: compounds 1, 4, 3 and 2 (each within the scatter of the next, the first and the last beyond it).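

In this assay the change on the aromatic carbon para to a hydroxy group gives a 1.1-fold lower number from compound 3 to compound 4 (0.06 log units; within the scatter) and, starting from the chloro compound, a 1.5-fold lower number from compound 2 to compound 4 (0.17 log units; within the scatter) within the same thioamide series. Chloro, bromo and trifluoromethyl are therefore not separated at this position, even though trifluoromethyl brings 4 heavy atoms in place of the single bromine. No measured data at hand bear on this flat read-out.

From the compounds shown here alone, whether the position stays this flat with a different kind of group, such as an amine, a carboxylic acid or a longer chain, remains open. Going by these compounds, it is also open whether trifluoromethyl would behave the same way in the amide of compound 1, which differs from the thioamides in more than one place.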